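The compounds below may be only part of what the source reports. "The series", "measured", "known", "first", "only" and "open" are said of these compounds alone.

In an ADME assay on L1210/0 cells (Mus musculus) for cytotoxicity, with a stated time of 48 h (on this read-out higher numbers stand for weaker inhibition and lower numbers for stronger inhibition), compound 1 (`COc1ccc(-c2ncnc3c2ncn3C[C@@H]2C[C@H](CO)c3ccccc32)cc1`) gives 17600 nM. Compound 2 (`Nc1ncnc2c1ncn2C[C@@H]1C[C@H](CO)c2ccccc21`) stands at > 200000 nM, which is a limit of the assay and not a number. Compound 3 (`COc1ncnc2c1ncn2C[C@@H]1C[C@H](CO)c2ccccc21`) has methoxy in place of amino on an aromatic carbon. Within the data shown here, the one measured step that bears on this is an at least 11-fold higher number from compound 1 to compound 2 (1.05 log units; beyond the scatter), a large change at the same carbon, though it involves 4-methoxyphenyl and not methoxy. It therefore carries over only in part. The expected step is an at least 1.8-fold lower number from compound 2 to compound 3 (0.25 log units; that floor lies within the scatter), a modest move toward stronger inhibition in this assay. For compound 3 the estimate is 110000 nM, with an expected range of 40000 nM to 200000 nM.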

Compound 3, half-maximal inhibitory concentration: > 200000 nM
Compound 3: only a limit was reported; the forecaster's own chance of this, stated with the estimate: 40%; middle value at least 1.8-fold (0.25 log units) away from the limit.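

Methoxy in place of 4-methoxyphenyl gives an at least 11-fold higher number from compound 1 to compound 3 (1.05 log units; beyond the scatter), so among the three compounds only the one with 4-methoxyphenyl on this aromatic carbon gives a measured number in this assay. Compound 2 and compound 3 both end at a limit of the assay and not a number, and the step between amino and methoxy cannot be read: the limit of > 200000 nM in this assay, at which 2 of the 3 values shown sit.

Open, as far as these compounds go, is how a plain phenyl or a dimethylamino group on this carbon would stand in this assay. Also open, from the compounds shown here alone, is whether an aromatic ring alone at this carbon is enough to bring the read-out down to a measured number.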